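Bromine to Chlorine on a Thioxothiazole Side Ring

This account rests on a few compounds, and the source may have more. Where it says the series, first, only, none or still open, it means among the compounds named here.

Compound 1 `COc1cc(N2C(=S)SCC2(O)c2ccc(Br)cc2)cc(OC)c1OC`: in a functional assay on MCF7 cells (Homo sapiens) for cytotoxicity, read by MTT assay, with a stated time of 48 h (a higher number here means a weaker inhibitor, a lower number a stronger inhibitor), compound 1 gives 16.5 ug/mL.
Compound 2 `COc1cc(-n2c(-c3ccccc3)csc2=S)cc(OC)c1OC`: in this assay compound 2 gives > 100 ug/mL, which is a limit of the assay and not a number.
Compound 3 `COc1cc(-n2c(-c3ccc(Br)cc3)csc2=S)cc(OC)c1OC`: in this assay compound 3 gives > 100 ug/mL, again a limit of the assay and not a number.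

Compound 3 therefore stands at the limit of > 100 ug/mL in this assay, at which 2 of the 3 values shown sit, and no number is known for it. The step from compound 2 to compound 3, a step that the two limits leave unreadable from compound 2 to compound 3, cannot be read because both ends sit at that limit. The compound not yet measured is compound 4 `COc1cc(-n2c(-c3ccc(Cl)cc3)csc2=S)cc(OC)c1OC`, which differs from compound 3 in one place: chloro in place of bromo on an aromatic carbon. For the measured compounds named here, no measured step speaks to this kind of change, and the only step that touches compound 3 is unreadable. With nothing in the measured compounds pointing to a gain, the expectation for compound 4 in this assay is that it stays at or near the limit where compound 3 sits, with a step that the limit leaves unreadable from compound 3 to compound 4 that means no change beyond the scatter. Compound 4 is thus estimated at 120 ug/mL, within a range from 50 ug/mL to 300 ug/mL.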

Compound 4, half-maximal inhibitory concentration: > 100 ug/mL
Compound 4: only a limit was reported (the forecaster's own chance of this, stated with the estimate: 85%); the middle value lies beyond the limit too.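

In this assay, for the compounds shown here, compound 4 gives > 100 ug/mL, a limit of the assay and not a number, so no step among compound 2, compound 3 and compound 4 can be read. These compounds share one mark: the limit of > 100 ug/mL in this assay, at which 3 of the 4 values shown sit.

The compounds shown leave open what true values lie behind that limit for compound 2, compound 3 and compound 4, and whether 4-bromophenyl and 4-chlorophenyl differ at all.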